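From 3-(diethylamino)propyl to butyl

A few compounds are considered here, and "the series" means these few. Any claim that something is new, unique, unknown or untested is made for them only; others in the source may bear on it.

Values measured in a functional assay on cells (Homo sapiens) for antiproliferative activity, read by MTT assay, with a stated time of 48 h (on this read-out lower numbers stand for stronger inhibition and higher numbers for weaker inhibition), for three compounds follow
compound 1 `N#Cc1nc2c(-c3nc4ccccc4[nH]3)c(N)n(CCN3CCCC3)c2nc1C#N` gives > 50000 nM as a limit of the assay
compound 2 `CN(C)CCCn1c(N)c(-c2nc3ccccc3[nH]2)c2nc(C#N)c(C#N)nc21` gives 1820 nM as a number
compound 3 `CCN(CC)CCCn1c(N)c(-c2nc3ccccc3[nH]2)c2nc(C#N)c(C#N)nc21` gives 28900 nM as a number

Compound 3 holds the higher of the two actual numbers, and compound 2 is the nearest value, lying lower by the large step of a 16-fold higher number from compound 2 to compound 3 (1.20 log units; beyond the scatter). The next compound, compound 4 `CCCCn1c(N)c(-c2nc3ccccc3[nH]2)c2nc(C#N)c(C#N)nc21`, is reached by one change methyl in place of diethylamino on a saturated chain carbon, three bonds along the chain from an aromatic nitrogen.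

Within the data shown here, three measured steps bear on this, and all of them alter only the amine end of the chain. The step of an at least 27-fold lower number from compound 1 to compound 2 (1.43 log units; beyond the scatter) is large, and so is the step from compound 2 to compound 3 already given. The step of an at least 1.7-fold lower number from compound 1 to compound 3 (0.23 log units; that floor lies within the scatter) has a floor within the scatter. These large steps run in opposite directions, and none of them removes the amino group altogether, so neither a size nor a direction carries over with confidence. No change beyond the scatter is therefore expected, with the estimated step being a 1.4-fold lower number from compound 3 to compound 4 (0.16 log units; within the scatter) in this assay, though a limit reading remains possible. The expected value for compound 4 is 20000 nM (estimated range 5000 nM to 50000 nM)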

Compound 4, half-maximal inhibitory concentration: > 50000 nM
Compound 4 ended at the assay's limit; the forecaster's own chance of this, stated with the estimate: 25%; at least 2.5-fold (0.39 log units) between middle value and limit.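

In this assay compound 4, whose butyl chain ends without any amine, gives > 50000 nM, which is a limit of the assay and not a number. This is the first compound shown with no amino group at the chain end, and the outcome depends on which amine it is compared with: an at least 27-fold higher number from compound 2 to compound 4 (1.43 log units; beyond the scatter) is large, leaving the dimethylamino end of compound 2 well ahead of plain butyl, whereas an at least 1.7-fold higher number from compound 3 to compound 4 (0.23 log units; that floor lies within the scatter) has a floor within the scatter, so no loss on removing the diethylamino end can be claimed. The step between compound 1 and compound 4 cannot be read, since both values are limits: the limit of > 50000 nM in this assay, at which 2 of the 4 values shown sit.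

Since compound 3 keeps its amine and still reads far weaker than compound 2, the presence of an amine alone does not set the level, and the compounds shown leave open what at the chain end does. As far as these compounds go, how a primary amine, a morpholine or a hydroxyl group there would read remains open, as does whether a longer chain ending in dimethylamino would hold the level of compound 2.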